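The source may report more compounds than this note shows. Statements on the series, on what has been measured and on what is new or still open speak of the compounds shown alone.

Values in a functional assay on thoracic aorta (Rattus norvegicus, strain Wistar), with a stated time of 15 min; a higher number here means that more compound is needed for the effect, a lower number that less compound is needed:
Compound 1 `COc1ccc(Cl)cc1C(C)NC(=O)NS(=O)(=O)c1ccccc1`: > 300000 nM
Compound 2 `COc1ccc(Cl)cc1C(C)NC(=O)N(C)S(=O)(=O)c1ccccc1`: 7200 nM

Compound 1 has no number in this assay, only a limit, > 300000 nM. Compound 3 `COc1ccc(Cl)cc1C(C)NC(=O)NS(=O)(=O)c1ccc(C)cc1` keeps the hydrogen on the amide-type nitrogen and differs from compound 1 elsewhere: methyl in place of hydrogen on an aromatic carbon, which is methyl in place of hydrogen on an aromatic carbon, or phenyl to 4-methylphenyl. For the measured compounds named here, the only measured step is an at least 41-fold lower number from compound 1 to compound 2 (1.61 log units; beyond the scatter). Going by the values given here, it is large, but it sits on the amide-type nitrogen, so it bears only indirectly on this change, and no measured step covers the aromatic carbon. No shift beyond the scatter is therefore expected in this assay, and a result at the limit again is quite likely. The expected step is a number no higher from compound 1 to compound 3 (the limit leaves the size open). For compound 3 the estimated value is 300000 nM, with an expected range of 80000 nM to 800000 nM.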

Compound 3, half-maximal effective concentration: > 300000 nM
Compound 3 ended at the assay's limit; the forecaster's own chance of this, stated with the estimate: 70%; the middle value sits exactly at the limit.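

Compound 1 and compound 3 both end at a limit in this assay, not at a number, so no step between them can be read: the limit of > 300000 nM in this assay, at which 2 of the 3 values shown sit.

The compounds shown leave open whether methyl in place of hydrogen on an aromatic carbon shifts the number at all.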